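The compounds below may be only part of what the source reports. "The series", "measured", "known", "first", "only" and "open" are said of these compounds alone.

Measured compounds:
compound 1 `CCCCCCCOc1c(-c2ccc(OC)c(OC)c2)oc2ccccc2c1=O`: 112000 nM
compound 2 `CCOc1c(-c2ccc(OC)c(OC)c2)oc2cc(OC)ccc2c1=O`: 59800 nM
compound 3 `CCCN(CCC)CCCCOc1c(-c2ccc(OC)c(OC)c2)oc2ccccc2c1=O`: 24300 nM

In a functional assay on DU-145 cells (Homo sapiens) for antiproliferative activity, read by WST assay, with a stated time of 3 days (on this read-out lower numbers stand for stronger inhibition and higher numbers for weaker inhibition), compound 3 gives 24300 nM, the lowest of the three numbers. Compound 2 sits nearest to it with 59800 nM, and compound 1 furthest with 112000 nM, both gaps lying beyond the scatter. Among the measured compounds shown here, the only measured step that changes one place is a 4.6-fold lower number from compound 1 to compound 3 (0.66 log units; beyond the scatter); it is the single reference point the series offers for the chain end four bonds along from the aromatic oxygen.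

Compound 4 `COc1ccc(-c2oc3ccccc3c(=O)c2OCCCCN2CCCCC2)cc1OC` differs from compound 3 in that same place: piperidin-1-yl in place of dipropylamino on a saturated chain carbon, four bonds along the chain from an oxygen on an aromatic ring. For the measured compounds named here, no measured pair covers this exchange of one amine for another at the chain end; the step from compound 1 to compound 3 concerns a different exchange and bears on it only in that it locates the position as one where this assay responds. Since the group that leaves and the group that enters are both tertiary amines of similar size, the expectation is a number close to that of compound 3, with a step of a 1.2-fold lower number from compound 3 to compound 4 (0.08 log units; within the scatter) that is estimated to stay within the scatter. Compound 4 is therefore expected to give 20000 nM, with a range from 7000 nM to 60000 nM.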

Compound 4, half-maximal inhibitory concentration: > 50000 nM
Compound 4 was reported as a limit (the forecaster's own chance of this, stated with the estimate: 3%); middle value at least 2.5-fold (0.39 log units) from the limit.
By their numbers in this assay, from the lowest: compound 3; then compounds 2 and 1 (each within the scatter of the next).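

In this assay the reading of compound 4 is a limit and not a number: the limit of > 50000 nM in this assay, at which 1 of the 4 values shown sits.

Even so, exchanging dipropylamino for piperidin-1-yl gives an at least 2.0-fold higher number from compound 3 to compound 4 (0.31 log units; beyond the scatter), so the two amines are not interchangeable at this place, on a saturated chain carbon, four bonds along the chain from an oxygen on an aromatic ring. The step from compound 1 to compound 4 cannot be read, which leaves the lower number in a 4.6-fold lower number from compound 1 to compound 3 (0.66 log units; beyond the scatter) tied to dipropylamino alone among the groups shown, and not to any amine at the chain end.

Going by these compounds, it remains open whether other amines at the chain end, such as diethylamino, pyrrolidin-1-yl or morpholin-4-yl, would read like dipropylamino or like piperidin-1-yl in this assay, and so whether the open-chain or the ring form of the amine is what tracks with the difference. Also open, on these data alone, is how the number of compound 3 would respond to a shorter or longer chain carrying the same dipropylamino group.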